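This account rests on a few compounds, and the source may have more. Where it says the series, first, only, none or still open, it means among the compounds named here.

Measured compounds in an assay on isolated protein for inhibition of Indoleamine 2,3-dioxygenase 1 (Homo sapiens), read by spectrophotometry; on this read-out lower numbers stand for stronger inhibition and higher numbers for weaker inhibition:
compound 1 `O=C(Cc1cccnc1)c1cc2c(O)cccc2[nH]1`, 83000 nM
compound 2 `O=C(Cc1cccnc1)c1cc2ccccc2[nH]1`, 65000 nM
compound 3 `O=C(Cc1cccnc1)c1cc2cc([N+](=O)[O-])ccc2[nH]1`, "not active" (no number reported)

Compound 2 has the lowest of the two reported numbers in this assay, but its nearest neighbour, compound 1, lies within the scatter of it: a 1.3-fold lower number from compound 1 to compound 2 (0.11 log units; within the scatter). Compound 3 returned no number in this assay, so it cannot be placed on the scale.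

The next compound, compound 4 `Cn1c(C(=O)Cc2cccnc2)cc2ccccc21`, is the unmeasured member of the series. Relative to compound 2 the difference is methyl in place of hydrogen on an aromatic nitrogen.

Within the data shown here, none of the measured steps touches the aromatic nitrogen; the only step known, a 1.3-fold lower number from compound 1 to compound 2 (0.11 log units; within the scatter), concerns an aromatic carbon and stayed within the scatter. Among the measured compounds shown here, there is therefore no measured precedent for the change from compound 2 to compound 4. For the measured compounds named here, with the two numbered compounds sitting close together and compound 3 giving no number at all, the series so far shows weak inhibition throughout, and nothing in it argues that this change would move the number beyond the scatter in either direction.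

Compound 4 is thus expected to give about 90000 nM in this assay, with a range from 30000 nM to 300000 nM; the expected step is a 1.4-fold higher number from compound 2 to compound 4 (0.14 log units; within the scatter).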

Compound 4, half-maximal inhibitory concentration: 34000 nM
Compound 4: the middle estimate sits 2.6-fold (0.42 log units) above what was measured; measured number inside the range.
By their numbers in this assay, from the lowest: compounds 4, 2 and 1 (each within the scatter of the next, the first and the last beyond it).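

In this assay, among these compounds, methyl in place of hydrogen on the aromatic nitrogen gives a 1.9-fold lower number from compound 2 to compound 4 (0.28 log units; within the scatter), the first measured step at this position of the series. The hydrogen on this nitrogen is therefore not needed for a number to be obtained, and with the methyl in place the inhibition remains weak and within the scatter of the unsubstituted parent. No measurement available bears on the reason for this result.

Only methyl has been shown on this nitrogen, so the compounds shown leave open whether an ethyl, a benzyl or a longer chain ending in an amine or a carboxylic acid would stay within the scatter or shift the number beyond it. They also leave open whether the methyl would behave the same way alongside the hydroxy of compound 1, or whether it would yield a number alongside the nitro group of compound 3, which gave none in this assay.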